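Swapping an Amide Substituent for a Trifluoromethyl Piperidine

This account rests on a few compounds, and the source may have more. Where it says the series, first, only, none or still open, it means among the compounds named here.

Measured compounds:
compound 1, `CCN(CC)S(=O)(=O)c1ccc(S(=O)(=O)N2CCC[C@@H](C(=O)N[C@H]3CC[C@H](OC)CC3)C2)cc1` — 2290 nM
compound 2, `CCN(CC)S(=O)(=O)c1ccc(S(=O)(=O)N2CCC[C@@H](C(=O)N3CCC(O)CC3)C2)cc1` — 230 nM
compound 3, `CCN(CC)S(=O)(=O)c1ccc(S(=O)(=O)N2CCC[C@@H](C(=O)NC3CCOCC3)C2)cc1` — 1350 nM

All three share one core and differ only in the group attached to the carbonyl carbon. In a functional assay on MIA PaCa-2 cells (Homo sapiens) for inhibition, read by MTT assay, with a stated time of 3 days (on this read-out lower numbers stand for stronger inhibition and higher numbers for weaker inhibition), compound 3 gives 1350 nM, the second highest of the three numbers; compound 1 lies nearest, within the scatter, and compound 2 lies furthest. The step of a 5.9-fold higher number from compound 2 to compound 3 (0.77 log units; beyond the scatter) separates the two.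

Compound 4, `CCN(CC)S(=O)(=O)c1ccc(S(=O)(=O)N2CCC[C@@H](C(=O)N3CCC(C(F)(F)F)CC3)C2)cc1`, is not yet measured. It differs from compound 3 by 4-(trifluoromethyl)piperidin-1-yl in place of (oxan-4-yl)amino on a carbonyl carbon. For the measured compounds named here, two measured steps bear on this: a 10-fold lower number from compound 1 to compound 2 (1.00 log units; beyond the scatter) and a 5.9-fold higher number from compound 2 to compound 3 (0.77 log units; beyond the scatter). Both show that replacing a ring attached through a nitrogen carrying a hydrogen-bond donor with a piperidin-1-yl ring joined directly to the carbonyl gave a clearly lower number. Whether the trifluoromethyl group behaves like the hydroxy group of compound 2 cannot be told from these data. On balance the expected step is a 3.0-fold lower number from compound 3 to compound 4 (0.48 log units; beyond the scatter), a lower number. Compound 4 is thus expected to give about 450 nM in this assay, within a range from 150 nM to 1500 nM.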

Compound 4, half-maximal inhibitory concentration: 110 nM
The estimate for compound 4 lay 4.1-fold (0.61 log units) above the measured number; the measured number lies below the stated range.
By their numbers in this assay, from the lowest: compound 4; then compound 2; then compounds 3 and 1 (each within the scatter of the next).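

In this assay compound 4 gives the lowest number of the four, with a 12-fold lower number from compound 3 to compound 4 (1.09 log units; beyond the scatter) and a 21-fold lower number from compound 1 to compound 4 (1.32 log units; beyond the scatter) as the large steps from the two compounds carrying an amide hydrogen. The hydroxy group of compound 2 proves not to be needed at this saturated ring carbon: a 2.1-fold lower number from compound 2 to compound 4 (0.32 log units; beyond the scatter) shows that trifluoromethyl gives a lower number, although the entering group counts no hydrogen-bond donors and no hydrogen-bond acceptors. Both compounds with a piperidin-1-yl ring on the carbonyl carbon now sit below both compounds with a ring attached through an amino nitrogen, and none of the four goes against this.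

From the compounds shown here alone, how a methyl group, a nitrile or a plain hydrogen at that ring carbon would compare with trifluoromethyl stays open. Nothing shown here explains any of these differences.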